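A Chlorine Added to Two Different Cores

The compounds below may be only part of what the source reports. "The series", "measured", "known", "first", "only" and "open" are said of these compounds alone.

The measured compounds, in a functional assay on MCF7 cells (Homo sapiens) for antiproliferative activity, read by MTT assay, with a stated time of 48 h; a higher number here means a weaker inhibitor, a lower number a stronger inhibitor:
compound 1, `O=C(Nc1nnc(-c2ccc(F)cc2)s1)c1ccccc1O`, 1210 nM
compound 2, `O=C(Nc1nnc(-c2ccc(F)cc2)s1)c1cc(Cl)ccc1O`, 750 nM
compound 3, `O=C(Nc1nnc(-c2ccccc2)s1)c1ccccc1`, 5870 nM

Compound 2 differs from compound 1 by chloro in place of hydrogen on an aromatic carbon, and the step is a 1.6-fold lower number from compound 1 to compound 2 (0.21 log units; within the scatter). Compound 3 gives the highest of the three numbers in this assay; how its core differs from that of compound 1 is not broken down here. Compound 4, `O=C(Nc1nnc(-c2ccccc2)s1)c1ccc(Cl)cc1`, has not been measured. It differs from compound 3 by chloro in place of hydrogen on an aromatic carbon. The same kind of change was made from compound 1 to compound 2, but the place is not the same: in compound 2 the chloro sits meta to a large group and para to a hydroxy group, while in compound 4 it sits para to a large group. Among the measured compounds shown here, with only one earlier step as a guide, a step of similar size, a 1.6-fold lower number from compound 3 to compound 4 (0.20 log units; within the scatter), is expected, because the earlier step was a 1.6-fold lower number from compound 1 to compound 2 (0.21 log units; within the scatter). Compound 4 is therefore estimated at 3700 nM in this assay, with a likely range from 1500 nM to 9000 nM.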

Compound 4, half-maximal inhibitory concentration: 4490 nM
For compound 4 the middle estimate is 1.2-fold (0.08 log units) below the measured one, and the stated range covers the measured number.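

In this assay, chloro in place of hydrogen gives a 1.3-fold lower number from compound 3 to compound 4 (0.12 log units; within the scatter), so on this core the change cannot be told apart from no change at all. Set beside the step on the core of compound 1, the change carries over with no difference that can be read: the same change on two cores in this assay, a 1.6-fold lower number (0.21 log units; within the scatter) from compound 1 to compound 2 and a 1.3-fold lower number (0.12 log units; within the scatter) from compound 3 to compound 4, 1.2-fold (0.09 log units) apart, within the scatter of two such steps This does not show that chloro lowers the number on either core, since both steps lie within the scatter, and the agreement is only one between two small steps, with the chloro standing at a different place on each core.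

The compounds shown leave open whether another group at the place para to a large group, such as an amine, a carboxylic acid or a longer chain, would give a step beyond the scatter. Also open, as far as these compounds go, is whether chloro would give a similar step at another place on the ring of compound 3, or on a third core.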